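Removing the isopropoxycarbonyl group from compound 1

This account rests on a few compounds, and the source may have more. Where it says the series, first, only, none or still open, it means among the compounds named here.

Three compounds have numbers in a functional assay on the whole organism with Scenedesmus acutus as the target, read by spectrophotometry; on this read-out higher numbers stand for weaker inhibition and lower numbers for stronger inhibition. Compound 1 `CC(C)OC(=O)c1cc(-n2c(=O)c3c([s+]2[O-])CCCC3)ccc1Cl` gives 50100 nM, the highest of the three and the weakest inhibitor so far, with both other numbers lower beyond the scatter. Compound 2 `O=c1c2c([s+]([O-])n1-c1cc(OC3CCCC3)c(Cl)cc1F)CCCC2` gives 4790 nM and compound 3 `CC(C)OC(=O)c1cc(-n2sc3c(c2=O)CCCC3)c(F)cc1Cl` gives 7240 nM. No two of these compounds differ in one place only, so no single change has been measured directly.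

Compound 4 `O=c1c2c([s+]([O-])n1-c1ccc(Cl)cc1)CCCC2` has not yet been measured. Relative to compound 1 it shows hydrogen in place of isopropoxycarbonyl on an aromatic carbon, ortho to a chloro group.

Compound 2 lacks that group at 4790 nM, while compound 3 carries it at 7240 nM, so these two numbers do not tie the group to a clear gain or loss. In this assay a small upward step is expected, perhaps none beyond the scatter. The estimated step is a 1.4-fold higher number from compound 1 to compound 4 (0.15 log units; within the scatter). For compound 4 the expected value is 70000 nM, with an estimated range of 22000 nM to 220000 nM.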

Compound 4, half-maximal inhibitory concentration: 21400 nM
The estimate for compound 4 lay 3.3-fold (0.51 log units) above the measured number, outside the stated range (below it).
By their numbers in this assay, from the lowest: compounds 2 and 3 (each within the scatter of the next); then compound 4; then compound 1.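

In this assay, hydrogen in place of isopropoxycarbonyl on this aromatic carbon, ortho to a chloro group, gives a 2.3-fold lower number from compound 1 to compound 4 (0.37 log units; beyond the scatter), a modest step beyond the scatter. Among these compounds, this is the first change that can be read in one place, and it shows that on the core of compound 1 the isopropoxycarbonyl group is not required for inhibition and that inhibition is stronger without it. The compounds shown offer nothing that explains the step.

From the compounds shown here alone, whether a methoxy group, a carboxylic acid or an amine at this position would give a number closer to that of compound 1 or compound 4 remains open. Also open, going by these compounds, is whether the same step holds when a fluoro group is present on the aromatic ring, as in compound 2 and compound 3.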